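Aminoamino in place of methylsulfanyl on compound 1

A few compounds are considered here, and "the series" means these few. Any claim that something is new, unique, unknown or untested is made for them only; others in the source may bear on it.

In a functional assay, with a stated time of 10 min (on this read-out higher numbers stand for weaker inhibition and lower numbers for stronger inhibition), compound 1 `CSc1nc(-c2ccco2)c(C#N)c(=O)n1C` gives 79 ug/mL. Compound 2 `CSc1nc(-c2cccs2)c(C#N)c(=O)n1C` gives 72 ug/mL, and compound 3 `CCOC(=O)c1cnn(-c2nc(-c3ccc(N(C)C)cc3)c(C#N)c(=O)n2C)c1N` gives 119 ug/mL. Compound 1 lies within the scatter of both. Compound 4 `Cn1c(NN)nc(-c2ccco2)c(C#N)c1=O` is not yet measured and carries aminoamino in place of methylsulfanyl on an aromatic carbon. For the measured compounds named here, the only measured step, a 1.1-fold lower number from compound 1 to compound 2 (0.04 log units; within the scatter), is thiophen-2-yl in place of furan-2-yl, a change at another place, and it stays within the scatter. Going by the values given here, no measured step touches methylsulfanyl, so the data give no direction. The expected change, a 1.0-fold higher number from compound 1 to compound 4 (0.01 log units; within the scatter), is none beyond the scatter. Compound 4 is estimated at 80 ug/mL, with an expected range of 35 ug/mL to 180 ug/mL.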

Compound 4, half-maximal inhibitory concentration: 58 ug/mL
Estimate against measurement, compound 4: 1.4-fold (0.14 log units) above; low and high end bracket the measured number.
By their numbers in this assay, from the lowest: compounds 4, 2, 1 and 3 (each within the scatter of the next, the first and the last beyond it).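

At the position between two ring nitrogen atoms, in this assay, aminoamino in place of methylsulfanyl gives a 1.4-fold lower number from compound 1 to compound 4 (0.13 log units; within the scatter) and stays within the scatter. For the compounds shown here, this is the first measured change at this position, and the two groups, with no atom in common, are not separated by the read-out.

As far as these compounds go, whether a plain amine, a methoxy group or a longer alkyl chain here would move the number beyond the scatter stays open. So does whether this step holds with thiophen-2-yl in place of furan-2-yl on the shared core. No supporting measurement bears on this result.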